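The compounds below may be only part of what the source reports. "The series", "measured", "known", "first", "only" and "open" are said of these compounds alone.

In a functional assay on SiHa cells (Homo sapiens) for inhibition (on this read-out lower numbers stand for stronger inhibition and higher numbers for weaker inhibition), compound 1 `COc1cc(/C=C/C(=O)c2cccc(NC(=O)c3ccco3)c2)ccc1O` gives 0.76 ug/mL, while compound 2 `COC(=O)C(=O)Nc1cccc(C(=O)/C=C/c2ccc(O)c(OC)c2)c1` gives 7.71 ug/mL, the higher of the two numbers and so the weaker inhibition. Compound 3 `COc1cc(/C=C/C(=O)c2cccc(NC(=O)c3ccccc3)c2)ccc1O` keeps the shared core and differs from compound 2 in one place: phenyl in place of methoxycarbonyl on a carbonyl carbon. For the measured compounds named here, only one measured step bears on this change, a 10-fold higher number from compound 1 to compound 2 (1.01 log units; beyond the scatter), which is large and beyond the scatter. In that step, methoxycarbonyl replaced furan-2-yl on the same carbonyl carbon. Compound 3 also loses methoxycarbonyl and carries a ring there, but phenyl is not furan-2-yl, and a single step shows no general pattern. Most of that large step, though not all of it, is therefore expected to be reversed. The expected change is a 5.1-fold lower number from compound 2 to compound 3 (0.71 log units; beyond the scatter), towards stronger inhibition. For compound 3, the estimated value is 1.5 ug/mL, with an expected range of 0.5 ug/mL to 5 ug/mL.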

Compound 3, half-maximal inhibitory concentration: 4.57 ug/mL
Compound 3: the middle estimate sits 3.0-fold (0.48 log units) below what was measured; measured number inside the range.
By their numbers in this assay, from the lowest: compound 1; then compounds 3 and 2 (each within the scatter of the next).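

In this assay, phenyl in place of methoxycarbonyl on this carbonyl carbon gives a 1.7-fold lower number from compound 2 to compound 3 (0.23 log units; within the scatter), so on this read-out these two groups cannot be told apart, even though only phenyl brings a ring. Phenyl in place of furan-2-yl on the same carbon gives a 6.0-fold higher number from compound 1 to compound 3 (0.78 log units; beyond the scatter), so this position does tell the two rings apart, and among these three compounds only the one carrying furan-2-yl stands out as the stronger inhibitor. Nothing given here explains this difference between the two rings.

Going by these compounds, whether the advantage belongs to furan-2-yl alone remains open, and a thiophen-2-yl or pyridinyl ring on this carbon would test that. A plain methyl group or a longer alkyl chain there would show how a group without a ring compares.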